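The compounds below may be only part of what the source reports. "The series", "measured", "known", "first", "only" and "open" are said of these compounds alone.

Measured compounds in a functional assay on HCT-116 cells (Homo sapiens) for antiproliferative activity, read by MTT assay, with a stated time of 48 h; on this read-out lower numbers stand for stronger inhibition and higher numbers for weaker inhibition:

Compound 1, `CCCCCCC(CCO)n1cnc2c(NC)ncnc21`, gives > 50000 nM; this value is a limit of the assay.
Compound 2, `CCCCCCC[C@@H](CCO)n1cnc2c(Cl)ncnc21`, gives 10700 nM.
Compound 3, `CCCCCCCC(CCO)n1cnc2c(NC)ncnc21`, gives 12500 nM.

Compound 3 differs from compound 1 by methyl in place of hydrogen on a saturated chain carbon, seven bonds along the chain from an aromatic nitrogen. The measured step is an at least 4.0-fold lower number from compound 1 to compound 3 (0.60 log units; beyond the scatter); it can only be given as an at-least figure because the limit of > 50000 nM in this assay, at which 1 of the 3 values shown sits, is where compound 1 sits. Compound 2 and compound 3 carry different cores; the difference between the two cores is not broken down here. In this assay the two values lie within the scatter of each other, so no order between compound 2 and compound 3 is claimed.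

Compound 4, `CCCCCCCC[C@@H](CCO)n1cnc2c(Cl)ncnc21`, is not yet measured. It differs from compound 2 by methyl in place of hydrogen on a saturated chain carbon, eight bonds along the chain from an aromatic nitrogen. Among the compounds with values here, this is the same kind of change as the one from compound 1 to compound 3, but the place is not identical: in the earlier pair the methyl enters on a saturated chain carbon seven bonds along the chain from an aromatic nitrogen, in the new pair on a saturated chain carbon eight bonds along the chain from an aromatic nitrogen.

For compound 4 in this assay the expected step is a 2.7-fold lower number from compound 2 to compound 4 (0.43 log units; beyond the scatter), set beside an at least 4.0-fold lower number from compound 1 to compound 3 (0.60 log units; beyond the scatter); the expectation rests on that measured step, tempered because that step is only an at-least figure anchored on the limit of > 50000 nM in this assay, at which 1 of the 3 values shown sits, and because the cores and the place of the change differ. Compound 4 is estimated at 4000 nM, with a range of 1500 nM to 12000 nM.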

Compound 4, half-maximal inhibitory concentration: 3400 nM
Beside the measured number, compound 4's estimate is 1.2-fold (0.07 log units) above it; the range from low to high includes it.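

In this assay, methyl in place of hydrogen on a saturated chain carbon, eight bonds along the chain from an aromatic nitrogen, gives a 3.1-fold lower number from compound 2 to compound 4 (0.50 log units; beyond the scatter), so on these two pairs the same kind of change lowers the number on both cores, although the place of the methyl is not identical between them. Set side by side, the two pairs read: the same change on two cores in this assay, an at least 4.0-fold lower number (0.60 log units; beyond the scatter) from compound 1 to compound 3 and a 3.1-fold lower number (0.50 log units; beyond the scatter) from compound 2 to compound 4; the limit leaves it open whether they differ. This does not show that the size of the step carries from one core to the other, and the open end of the comparison is compound 1, whose > 50000 nM is a limit of the assay and not a number: the limit of > 50000 nM in this assay, at which 1 of the 4 values shown sits.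

The compounds shown leave open whether the trend in these two pairs continues with a longer chain than that of compound 4, or whether it stops or reverses at some length. They also leave open how the series would respond to an amine or a carboxylic acid in place of the hydroxyl, and whether the same methyl step would then still appear on either core.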